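This account rests on a few compounds, and the source may have more. Where it says the series, first, only, none or still open, it means among the compounds named here.

Measured so far in an assay on isolated protein for inhibition of ubiquitin carboxyl-terminal hydrolase 7 (Homo sapiens), with stated times of 30 min and 2 h; on this read-out lower numbers stand for stronger inhibition and higher numbers for weaker inhibition:
compound 1, `Cn1nc2c(=O)n(CC3(O)CCN(Cc4ccc(-c5ccco5)cc4Cl)CC3)cnc2c1-c1ccc(C2(N)CC2)cc1`: 66.1 nM
compound 2, `Cn1nc2c(=O)n(CC3(O)CCN(Cc4ccc(-c5ccco5)cc4Cl)CC3)cnc2c1-c1ccc(CNC=O)cc1`: 20.9 nM
compound 3, `Cn1nc2c(=O)n(CC3(O)CCN(Cc4ccc(-n5ccnc5)cc4Cl)CC3)cnc2c1-c1ccc(CN)cc1`: 228 nM

Compound 1 stands second highest of the three numbers in this assay; the nearest number is that of compound 2, the furthest that of compound 3. Compound 4, `CCCNCc1ccc(-c2c3ncn(CC4(O)CCN(Cc5ccc(-c6ccco6)cc5Cl)CC4)c(=O)c3nn2C)cc1`, has not yet been measured. It differs from compound 1 in one place: (propylamino)methyl in place of 1-aminocyclopropyl on an aromatic carbon.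

Among the measured compounds shown here, one measured step bears on this change directly, as it replaces the same 1-aminocyclopropyl on the same aromatic carbon: a 3.2-fold lower number from compound 1 to compound 2 (0.50 log units; beyond the scatter). Compound 3 also carries an open-chain amine on that ring, but its other aryl group differs as well from compound 1, so no single-change step links them; its number is simply the highest of the three shown. The step from compound 1 to compound 2 is modest and beyond the scatter, and no second comparison checks whether a longer chain on the nitrogen behaves the same way.

The expectation for compound 4 is therefore a lower number than compound 1 in this assay, of a size similar to or smaller than that step, with the range wide enough to include no change beyond the scatter. Compound 4 is estimated at 40 nM, between 15 nM and 120 nM. That estimate corresponds to a step of a 1.7-fold lower number from compound 1 to compound 4 (0.22 log units; within the scatter).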

Compound 4, half-maximal inhibitory concentration: 43.9 nM
Compound 4: middle estimate off by 1.1-fold (0.04 log units), on the low side; low and high end bracket the measured number.
By their numbers in this assay, from the lowest: compound 2; then compounds 4 and 1 (each within the scatter of the next); then compound 3.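

In this assay, replacing 1-aminocyclopropyl with (propylamino)methyl on the aromatic carbon para to a large group gives a 1.5-fold lower number from compound 1 to compound 4 (0.18 log units; within the scatter), so at this position an open chain with no ring stands level with the three-membered ring, although the entering group has one more heavy atom. The substituent on the amine nitrogen does register at this position: propyl in place of formyl gives a 2.1-fold higher number from compound 2 to compound 4 (0.32 log units; beyond the scatter), a modest step beyond the scatter that is seen in this single pair and places the formyl compound at the lower number. Nothing available accounts for either step, whether through the ring, the chain or the formyl group.

Whether the difference between propyl and formyl reflects the chain itself remains open, since shorter or longer chains such as methyl, ethyl or butyl on that nitrogen, or an acetyl in place of formyl, are absent from the compounds shown. Compound 3 differs from each of the other compounds in more than one place, so its steps to them cannot be read, and the effect of its open-chain amine at this position remains unresolved.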